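This account rests on a few compounds, and the source may have more. Where it says the series, first, only, none or still open, it means among the compounds named here.

Measured in an assay on HEK293 cells for binding affinity to 5-hydroxytryptamine receptor 7 (Homo sapiens), read by radioligand binding, tested at 1 uM; a lower number here means less inhibition, a higher number more inhibition at the concentration tested (going by the name of the read-out):
compound 1 `CN1CCCN(CCn2ccc3ccc(Br)cc32)CC1` gives 93%
compound 2 `CCc1ccc2ccn(CCN3CCCN(C)CC3)c2c1` gives 66%
compound 3 `CN1CCCN(CCn2ccc3ccc(-c4cccnc4)cc32)CC1` gives 35%

Compound 3 stands lowest of the three numbers in this assay: its nearest neighbour is compound 2, and the gap between them, a number 31 percentage points lower from compound 2 to compound 3 (beyond the scatter), is beyond the scatter, while the gap to compound 1, a number 58 percentage points lower from compound 1 to compound 3 (beyond the scatter), is larger still. The not yet measured compound 4 `CN1CCCN(CCn2ccc3ccc(-c4ccsc4)cc32)CC1` differs from compound 3 in one place: thiophen-3-yl in place of pyridin-3-yl on an aromatic carbon. Within the data shown here, no measured step swaps one aromatic ring for another, so only indirect guidance exists. The two steps that replace bromo with a larger group, a number 27 percentage points lower from compound 1 to compound 2 (beyond the scatter) and a number 58 percentage points lower from compound 1 to compound 3 (beyond the scatter), both lower the read-out, and the step of a number 31 percentage points lower from compound 2 to compound 3 (beyond the scatter) shows that the six-membered ring with one nitrogen gives the lowest number of all. Since thiophen-3-yl is smaller than pyridin-3-yl and closer in size to ethyl, a modest rise from compound 3 is expected, a number 15 percentage points higher from compound 3 to compound 4 (beyond the scatter), though a change within the scatter cannot be excluded. For compound 4 the estimated value in this assay is 50%, with a range from 25% to 75%.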

Compound 4, a percentage reported as inhibition, at one concentration (the size of the read-out at that concentration, not a potency): 68%
Beside the measured number, compound 4's estimate is 18 percentage points below it; measured number inside the range.
By their numbers in this assay, from the lowest: compound 3; then compounds 2 and 4 (each within the scatter of the next); then compound 1.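

In this assay, among these compounds, this position proves sensitive to which aromatic ring it carries, not only to the loss of bromo: thiophen-3-yl, a five-membered ring, in place of pyridin-3-yl, a six-membered one, gives a number 33 percentage points higher from compound 3 to compound 4 (beyond the scatter) in the only step here that swaps one aromatic ring for another. Thiophen-3-yl does not read apart from ethyl, with a number 2 percentage points higher from compound 2 to compound 4 (within the scatter) as that step, while bromo still reads apart from it, with a number 25 percentage points lower from compound 1 to compound 4 (beyond the scatter) as the step, so an aromatic ring at this position need not bring the read-out down as far as pyridin-3-yl does. No evidence is available that accounts for the difference between the two rings. Pyridin-3-yl and thiophen-3-yl differ in ring size and in hetero atom at once, which leaves open which of the two goes with the step. On these data alone, how a plain phenyl ring or a furan-3-yl ring would read at this position also remains open.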